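The source may report more compounds than this note shows. Statements on the series, on what has been measured and on what is new or still open speak of the compounds shown alone.

The series keeps one shared core and varies only the substituent on the sulfonamide nitrogen. Compound 1 `CCCCCCNS(=O)(=O)NC(=O)Oc1c(C(C)C)cccc1C(C)C` gives 21000 nM in an assay on liver for inhibition of sterol O-acyltransferase 1 (Rattus norvegicus), using microsomes; on this read-out lower numbers stand for stronger inhibition and higher numbers for weaker inhibition. Compound 2 `CC(C)c1cccc(C(C)C)c1OC(=O)NS(=O)(=O)N(c1ccccc1)c1ccccc1` gives 58000 nM in this assay. Compound 3 `CC(C)c1cccc(C(C)C)c1OC(=O)NS(=O)(=O)Nc1ccccc1` gives 38100 nM in this assay; written out, this is the second highest of the three numbers, but its gaps to compound 1 and to compound 2 both lie within the scatter, so no ranking among the three can be read from them. The two steps into compound 3 are a 1.8-fold higher number from compound 1 to compound 3 (0.26 log units; within the scatter) and a 1.5-fold lower number from compound 2 to compound 3 (0.18 log units; within the scatter): hexyl, phenyl and hydrogen at this nitrogen all left the read-out essentially unchanged. Compound 4 `CC(C)c1cccc(C(C)C)c1OC(=O)NS(=O)(=O)Nc1nc2ccccc2[nH]1` is not yet measured. It differs from compound 3 by 1H-benzimidazol-2-yl in place of phenyl on a sulfonamide nitrogen. Both measured steps at the same position stayed within the scatter, so for compound 4 no step beyond the scatter is expected in this assay in either direction; the incoming group does carry a hydrogen-bond donor and acceptor absent from all earlier substituents, so the range is kept wide. Compound 4 is therefore expected near 35000 nM, between 10000 nM and 120000 nM. The expected step is a 1.1-fold lower number from compound 3 to compound 4 (0.04 log units; within the scatter).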

Compound 4, half-maximal inhibitory concentration: 52000 nM
Compound 4: middle estimate off by 1.5-fold (0.17 log units), on the low side, and the stated range covers the measured number.
By their numbers in this assay, from the lowest: compounds 1, 3, 4 and 2 (each within the scatter of the next, the first and the last beyond it).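

In this assay, 1H-benzimidazol-2-yl in place of phenyl on the sulfonamide nitrogen gives a 1.4-fold higher number from compound 3 to compound 4 (0.14 log units; within the scatter), so even a larger group with a hydrogen-bond donor and acceptor, both absent from phenyl, cannot be told apart from phenyl here. Going by these compounds alone, the same group in place of hexyl gives the first step at this position beyond the scatter, a 2.5-fold higher number from compound 1 to compound 4 (0.39 log units; beyond the scatter), a modest move towards weaker inhibition. Since phenyl and hexyl themselves lie within the scatter of each other, this step marks the ends of a narrow spread and does not set the 1H-benzimidazol-2-yl group apart from phenyl.

As far as these compounds go, whether an amine or a carboxylic acid at the end of the hexyl chain, or a chain longer than hexyl, would move the read-out well outside this band stays open. Nothing available explains the small differences seen at this position.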